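A few compounds are considered here, and "the series" means these few. Any claim that something is new, unique, unknown or untested is made for them only; others in the source may bear on it.

In a functional assay on DU-145 cells (Homo sapiens) for inhibition, read by trypan blue exclusion, with a stated time of 96 h (on this read-out lower numbers stand for stronger inhibition of growth and higher numbers for weaker inhibition of growth), three related compounds have been measured. Compound 1 `COc1ccccc1/C=C(\C(=O)c1ccc(Cl)cc1)S(=O)(=O)Cc1ccc(Cl)cc1` gives 25000 nM, compound 2 `Cc1ccc(C)c(/C=C(\C(=O)c2ccc(Cl)cc2)S(=O)(=O)c2ccc(Br)cc2)c1` gives 1000 nM, and compound 3 `COc1ccccc1/C=C(\C(=O)c1ccc(Cl)cc1)S(=O)(=O)c1ccc(Br)cc1` gives 10000 nM, which places compound 3 in the middle of the three numbers.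

The next compound, compound 4 `COc1ccc(/C=C(\C(=O)c2ccc(Cl)cc2)S(=O)(=O)c2ccc(Br)cc2)cc1O`, has 3-hydroxy-4-methoxyphenyl in place of the 2-methoxyphenyl of compound 3, on a double-bonded chain carbon bound to a double-bonded chain carbon. The change is 3-hydroxy-4-methoxyphenyl in place of 2-methoxyphenyl on a double-bonded chain carbon bound to a double-bonded chain carbon.

The measured step that bears most directly on this is a 10-fold higher number from compound 2 to compound 3 (1.00 log units; beyond the scatter), with 2-methoxyphenyl in place of 2,5-dimethylphenyl at the same place. The other step, a 2.5-fold lower number from compound 1 to compound 3 (0.40 log units; beyond the scatter), with 4-bromophenyl in place of 4-chlorobenzyl on a sulfonyl sulfur, concerns a different place and says little here.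

Among the measured compounds shown here, no measured compound carries the 3-hydroxy-4-methoxyphenyl group, and the direction remains uncertain. The expectation rests on compound 2, which gives 1000 nM with a different group at this place. The expected step is a 5.0-fold lower number from compound 3 to compound 4 (0.70 log units; beyond the scatter), a modest move toward stronger inhibition of growth.

For compound 4 the estimated value is 2000 nM, with an expected range from 200 nM to 15000 nM.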

Compound 4, concentration for 50% growth inhibition: 10000 nM
For compound 4 the middle estimate is 5.0-fold (0.70 log units) below the measured one; the measured number falls inside the stated range.
By their numbers in this assay, from the lowest: compound 2; then compounds 3 and 4 (each within the scatter of the next); then compound 1.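

In this assay, placing 3-hydroxy-4-methoxyphenyl where compound 3 has 2-methoxyphenyl gives no change at the digits printed from compound 3 to compound 4 (within the scatter), so this position tolerates this exchange without a readable difference in growth inhibition. Among the compounds shown here, the 2,5-dimethylphenyl group of compound 2 still stands apart, with a 10-fold higher number from compound 2 to compound 4 (1.00 log units; beyond the scatter) matching the earlier 10-fold higher number from compound 2 to compound 3 (1.00 log units; beyond the scatter), so among the three groups seen at this place, the two carrying oxygen read alike and the one carrying only methyl groups gives the lowest number. No measurement on these compounds offers a reason for this pattern.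

The compounds shown leave open whether the lower number of compound 2 needs both methyl groups, which a 2-methylphenyl or a 3-methylphenyl group at the same place would help to settle. They also leave open how the number would respond to a quite different group on this ring, such as an amine or a carboxylic acid.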